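Working notes: from 3-chlorophenyl to 4-methylphenyl

A few compounds are considered here, and "the series" means these few. Any claim that something is new, unique, unknown or untested is made for them only; others in the source may bear on it.

- compound 1 `COc1cc(-n2cnc3ccc(-c4ccc(C)cc4F)cc32)cc(OC)c1OC`: 5650 nM
- compound 2 `COc1ccc(-c2ccc3ncn(-c4cc(OC)c(OC)c(OC)c4)c3c2)cc1F`: 430 nM
- compound 3 `COc1cc(-n2cnc3ccc(-c4cccc(Cl)c4)cc32)cc(OC)c1OC`: 1490 nM

In a functional assay on SGC-7901 cells (Homo sapiens) for antiproliferative activity, read by MTT assay, with a stated time of 72 h (on this read-out higher numbers stand for weaker inhibition and lower numbers for stronger inhibition), compound 3 gives 1490 nM, the middle of the three numbers. The two steps that reach it are a 3.5-fold higher number from compound 2 to compound 3 (0.54 log units; beyond the scatter) and a 3.8-fold lower number from compound 1 to compound 3 (0.58 log units; beyond the scatter).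

The next compound is compound 4 `COc1cc(-n2cnc3ccc(-c4ccc(C)cc4)cc32)cc(OC)c1OC`, not yet measured. It has 4-methylphenyl in place of 3-chlorophenyl on an aromatic carbon.

Going by the values given here, no measured pair isolates this change. The closest evidence is compound 1, whose 2-fluoro-4-methylphenyl group most resembles the entering group, and a 3.8-fold lower number from compound 1 to compound 3 (0.58 log units; beyond the scatter) runs in favour of 3-chlorophenyl. The wider a 13-fold lower number from compound 1 to compound 2 (1.12 log units; beyond the scatter) shows that exchanging this aryl group alone can produce a large step, so the uncertainty is broad. In this assay a modest rise is expected, and the estimated step is a 2.1-fold higher number from compound 3 to compound 4 (0.33 log units; beyond the scatter). The estimate for compound 4 is 3200 nM, with an expected range from 1000 nM to 9000 nM.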

Compound 4, half-maximal inhibitory concentration: 200 nM
Compound 4: the middle estimate sits 16-fold (1.20 log units) above what was measured; the measured number lies below the stated range.
By their numbers in this assay, from the lowest: compound 4; then compound 2; then compound 3; then compound 1.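

In this assay, going by these compounds alone, the step of a 28-fold lower number from compound 1 to compound 4 (1.45 log units; beyond the scatter), with hydrogen in place of fluoro, is the first pair to isolate a single substituent on this aryl group, and it places the high number of compound 1 on the fluoro of 2-fluoro-4-methylphenyl rather than on the 4-methylphenyl group itself. The step of a 7.5-fold lower number from compound 3 to compound 4 (0.87 log units; beyond the scatter) reverses the ranking that compound 1 had suggested against 3-chlorophenyl, and the step of a 2.2-fold lower number from compound 2 to compound 4 (0.33 log units; beyond the scatter) leaves compound 4 with the lowest number of the four, although compound 2 also carries a fluoro, so no general penalty for fluoro can be claimed. Nothing measured here bears on why these steps run as they do. Still open, as far as these compounds go, is how an ethyl, an amine or a carboxylic acid would compare with the methyl of 4-methylphenyl.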